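Removing One Methoxy Group: Expected Effect on Growth Inhibition

This account rests on a few compounds, and the source may have more. Where it says the series, first, only, none or still open, it means among the compounds named here.

Compound 1 `COc1cc(-c2cc(/C=C/C(=O)c3ccc(N)cc3)[nH]n2)cc(OC)c1OC`: 4820 nM
Compound 2 `COc1ccc(-c2cc(/C=C/C(=O)c3ccc(N)cc3)[nH]n2)cc1OC`: 6910 nM
Compound 3 `COc1cc(C(=O)/C=C/c2cc(-c3cc(OC)c(OC)c(OC)c3)n[nH]2)cc(OC)c1OC`: 3370 nM

These three compounds were tested in a functional assay on HT-29 cells (Homo sapiens) for inhibition, read by sulforhodamine B assay, with a stated time of 48 h; a higher number here means a weaker inhibitor of growth, a lower number a stronger inhibitor of growth. Compound 1 and compound 2 differ in one place: hydrogen in place of methoxy on an aromatic carbon. This gave a 1.4-fold higher number from compound 1 to compound 2 (0.16 log units; within the scatter). Compound 3 gives a number within the scatter of compound 1, and only against compound 2 does the gap lie beyond the scatter. How the core of compound 3 differs from the core of compound 1 is not broken down here.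

Compound 4 `COc1ccc(-c2cc(/C=C/C(=O)c3cc(OC)c(OC)c(OC)c3)[nH]n2)cc1OC` has not yet been measured. For the measured compounds named here, it differs from compound 3 by hydrogen in place of methoxy on an aromatic carbon, which is the same change as the one from compound 1 to compound 2, at a place described in the same words. In this assay compound 4 is therefore expected to show a step of a 1.4-fold higher number from compound 3 to compound 4 (0.14 log units; within the scatter), close to the earlier step, because the same change gave a 1.4-fold higher number from compound 1 to compound 2 (0.16 log units; within the scatter). The estimated value for compound 4 in this assay is 4700 nM, expected to fall between 2400 nM and 9500 nM.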

Compound 4, concentration for total growth inhibition: 2730 nM
For compound 4 the middle estimate is 1.7-fold (0.24 log units) above the measured one, and the stated range covers the measured number.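

Replacing the methoxy group with hydrogen on the core of compound 3 gave a 1.2-fold lower number from compound 3 to compound 4 (0.09 log units; within the scatter) in this assay, so on this core, as on the core of compound 1, the step stays within the scatter. Set side by side, the two steps cannot be told apart: the same change on two cores in this assay, a 1.4-fold higher number (0.16 log units; within the scatter) from compound 1 to compound 2 and a 1.2-fold lower number (0.09 log units; within the scatter) from compound 3 to compound 4, 1.8-fold (0.25 log units) apart, within the scatter of two such steps. This shows that the change carried over from one core to the other without a step beyond the scatter, but steps this small do not settle whether it pushes the number the same way on both cores, and two pairs give no rule for other cores.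

The compounds shown leave open what happens when this methoxy group gives way to something other than hydrogen, such as a hydroxyl group, a fluorine atom or a longer chain like ethoxy. They also leave open whether the step would stay this small in any other assay.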